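Chloro for Methyl on a Two-Ring Core, Second Pairing

This account rests on a few compounds, and the source may have more. Where it says the series, first, only, none or still open, it means among the compounds named here.

Compound 1, `Cc1ccc2c(C3CCN(CCN4CCNC4=O)CC3)cn(-c3ccc(F)cc3)c2c1`, carries a methyl on an aromatic carbon of its two-ring system. In an assay on cell membranes for displacement of a labelled ligand from Adrenergic receptor alpha-1 (Rattus norvegicus) (on this read-out higher numbers stand for weaker inhibition and lower numbers for stronger inhibition), compound 1 gives 24 nM. Compound 2, `O=C1NCCN1CCN1CCC(c2cn(-c3ccc(F)cc3)c3cc(Cl)ccc23)CC1`, is the same structure with chloro in place of methyl on an aromatic carbon, and in this assay compound 2 gives 9.6 nM; the result is a 2.5-fold lower number from compound 1 to compound 2 (0.40 log units; beyond the scatter).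

Compound 3, `Cc1ccc2c(C3CCN(CCN4CCN(C(C)C)C4=O)CC3)c[nH]c2c1`, rests on a different core, and the difference between the two cores is not broken down here. In this assay compound 3 gives 27 nM, a value within the scatter of compound 1 and beyond it from compound 2.

Compound 4, `CC(C)N1CCN(CCN2CCC(c3c[nH]c4cc(Cl)ccc34)CC2)C1=O`, has not yet been measured. It differs from compound 3 by chloro in place of methyl on an aromatic carbon, the same change, at a place described in the same words, as that from compound 1 to compound 2. The expected step for compound 4 is therefore a 2.5-fold lower number from compound 3 to compound 4 (0.39 log units; beyond the scatter), because the measured pair showed a 2.5-fold lower number from compound 1 to compound 2 (0.40 log units; beyond the scatter). For compound 4 in this assay the estimate is 11 nM, within a range from 5 nM to 24 nM.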

Compound 4, half-maximal inhibitory concentration: 34 nM
For compound 4 the middle estimate is 3.1-fold (0.49 log units) below the measured one; the whole stated range lies below it.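

In this assay, chloro in place of methyl on an aromatic carbon gives a 1.3-fold higher number from compound 3 to compound 4 (0.10 log units; within the scatter), so the step seen on the core of compound 1 is not repeated on the core of compound 3. Set side by side, the two steps do not agree: the same change on two cores in this assay, a 2.5-fold lower number (0.40 log units; beyond the scatter) from compound 1 to compound 2 and a 1.3-fold higher number (0.10 log units; within the scatter) from compound 3 to compound 4, 3.1-fold (0.50 log units) apart, beyond the scatter of two such steps. This shows that, for these two pairs, the step measured on one core could not be carried over to the other; it does not show which part of the structure sets the two apart, as compound 1 and compound 3 differ in more than one place, and two pairs give no rule for the series as a whole.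

Still open, as far as these compounds go, is how a bromo or a methoxy on that aromatic carbon would compare with methyl and chloro on either core. Also open, from the compounds shown here alone, is which of the two steps, if either, the same change would follow on a third core.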